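Side-chain exchange from compound 3 to compound 4

This account rests on a few compounds, and the source may have more. Where it says the series, first, only, none or still open, it means among the compounds named here.

Measured in a functional assay with Oryctolagus cuniculus as the target; a lower number here means a stronger inhibitor, a higher number a weaker inhibitor:
- compound 1 `COc1ccc(-c2nc(N=C(N)N)sc2-c2ccc(OC)cc2)cc1`: 31000 nM
- compound 2 `COc1ccc(-c2nc(/N=C(\N)N(C)C)sc2-c2ccc(OC)cc2)cc1`: 37 nM
- compound 3 `COc1ccc(-c2nc(CNC(=O)N3CCOCC3)sc2-c2ccc(OC)cc2)cc1`: 660 nM

Compound 3 stands second highest of the three numbers. Its two measured steps are a 47-fold lower number from compound 1 to compound 3 (1.67 log units; beyond the scatter) and an 18-fold higher number from compound 2 to compound 3 (1.25 log units; beyond the scatter).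

Next is compound 4 `COc1ccc(-c2nc(C(=O)N3CCCCC3)sc2-c2ccc(OC)cc2)cc1`, which keeps the shared core and carries (piperidin-1-yl)carbonyl in place of (((morpholin-4-yl)carbonyl)amino)methyl on an aromatic carbon.

All measured steps change this same place and all are large; the third is an 840-fold lower number from compound 1 to compound 2 (2.92 log units; beyond the scatter). Large steps are therefore possible here in this assay, but none of them involves the entering group, and they give no direction for it. The expectation stays anchored on compound 3 at 660 nM, with no firm step beyond the scatter in either direction and a wide margin. The expected change is a 1.5-fold lower number from compound 3 to compound 4 (0.17 log units; within the scatter). For compound 4 the estimated value is 450 nM, with an expected range from 50 nM to 3500 nM.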

Compound 4, half-maximal inhibitory concentration: > 1000 nM
Compound 4 gave a limit, no number; the forecaster's own chance of this, stated with the estimate: 5%; at least 2.2-fold (0.34 log units) between middle value and limit.
By their numbers in this assay, from the lowest: compound 2; then compound 3; then compound 1.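

In this assay compound 4 gives > 1000 nM, which is a limit and not a number. Replacing (((morpholin-4-yl)carbonyl)amino)methyl with (piperidin-1-yl)carbonyl on this aromatic carbon gives an at least 1.5-fold higher number from compound 3 to compound 4 (0.18 log units; that floor lies within the scatter), so the result shows no firm change from compound 3, though a larger loss remains possible. The new side chain, with 0 hydrogen-bond donors, does not reach the level of compound 2, as shown by an at least 27-fold higher number from compound 2 to compound 4 (1.43 log units; beyond the scatter), while the step from compound 1 cannot be read.

The ring and the link to the shared core change together from compound 3 to compound 4, so their separate contributions remain unresolved. Also open, from the compounds shown here alone, is how a primary amine or a carboxylic acid on this aromatic carbon would read in this assay.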